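The source may report more compounds than this note shows. Statements on the series, on what has been measured and on what is new or still open speak of the compounds shown alone.

Compound 1 `Clc1ccc(Nc2ccc(N3CC4CC(C3)N4)cn2)cc1` stands lowest of the two numbers measured: in an assay on cell membranes for displacement of a labelled ligand from Neuronal acetylcholine receptor; alpha4/beta2 (Rattus norvegicus) (on this read-out lower numbers stand for stronger inhibition and higher numbers for weaker inhibition), compound 1 gives 2.49 nM, whereas compound 2 `CN(c1ccccc1)c1ccc(N2CC3CC(C2)N3)nn1` gives 1430 nM in this assay, a gap far beyond the scatter. Compound 3 `FC(F)(F)c1ccc(Nc2ccc(N3CC4CC(C3)N4)cn2)cc1` differs from compound 1 in one place, (trifluoromethyl in place of chloro on an aromatic carbon), trifluoromethyl in place of chloro on an aromatic carbon, para to a large group. Within the data shown here, no measured pair shows this exchange, so the expectation rests on the change itself: a small step, at most near the edge of the scatter, leaning toward a higher number. The expected step is a 1.6-fold higher number from compound 1 to compound 3 (0.21 log units; within the scatter). Compound 3 is estimated at 4 nM, between 1.5 nM and 12 nM.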

Compound 3, inhibition constant: 0.569 nM
The estimate for compound 3 lay 7.0-fold (0.85 log units) above the measured number; the measured number lies below the stated range.
By their numbers in this assay, from the lowest: compound 3; then compound 1; then compound 2.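

On the aromatic carbon para to a large group, the shared core accepts more than chloro: in this assay, trifluoromethyl in place of chloro gives a 4.4-fold lower number from compound 1 to compound 3 (0.64 log units; beyond the scatter). Four heavy atoms thus stand where one stood, and the number still falls, which the two earlier compounds, differing in more than one place, could not show. Nothing shown here accounts for this drop. On these data alone, it remains open how a methoxy group, a nitrile or an amine would fare at this position. As far as these compounds go, whether the same exchange gives a similar step on another core also remains open.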